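Moving a hydroxyl around a pyridine-flanking phenyl ring

This account rests on a few compounds, and the source may have more. Where it says the series, first, only, none or still open, it means among the compounds named here.

Measured so far:
compound 1 `Oc1cccc(-c2cc(-c3ccsc3)cc(-c3cccc(O)c3)n2)c1` — 1630 nM
compound 2 `Oc1cccc(-c2cc(-c3ccco3)cc(-c3ccccc3O)n2)c1` — > 50000 nM

In a functional assay on HCT-15 cells (Homo sapiens) for cytotoxicity, read by CCK-8 assay (on this read-out higher numbers stand for weaker inhibition and lower numbers for stronger inhibition), compound 1 gives 1630 nM. For compound 2 the result is only a limit of this assay, > 50000 nM, so no number is known for it; it sits at the limit of > 50000 nM in this assay, at which 1 of the 2 values shown sits.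

Compound 3 `Oc1cccc(-c2cc(-c3ccco3)cc(-c3cccc(O)c3)n2)c1` has not yet been tested in this assay. It differs from compound 2 by 3-hydroxyphenyl in place of 2-hydroxyphenyl on an aromatic carbon. Among the measured compounds shown here, no step between two measured compounds covers this change. Compound 3 carries two 3-hydroxyphenyl groups, as compound 1 does, and compound 1 gives a real number in this assay, so the move from compound 2 to compound 3 is expected to bring a clear gain in inhibition, well beyond the scatter, as an at least 14-fold lower number from compound 2 to compound 3 (1.15 log units; beyond the scatter). Compound 3 is therefore estimated at 3500 nM in this assay, within 900 nM to 15000 nM.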

Compound 3, half-maximal inhibitory concentration: 1890 nM
Compound 3: middle estimate off by 1.9-fold (0.27 log units), on the high side; measured number inside the range.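

In this assay, at this place next to the ring nitrogen, 3-hydroxyphenyl in place of 2-hydroxyphenyl gives an at least 26-fold lower number from compound 2 to compound 3 (1.42 log units; beyond the scatter), so with the same atoms joined differently, the place of the hydroxyl on this one ring separates a measurable value from none. As far as these compounds go, the value of compound 2 is only a limit of the assay, so the true size of this step stays unknown: the limit of > 50000 nM in this assay, at which 1 of the 3 values shown sits. With two 3-hydroxyphenyl groups present, furan-2-yl in place of thiophen-3-yl gives a 1.2-fold higher number from compound 1 to compound 3 (0.06 log units; within the scatter), so this assay does not tell these two groups apart.

The compounds shown leave open whether the hydroxyl itself matters, as they do not show how a methoxy or an amine would stand in its place. From the compounds shown here alone, how 4-hydroxyphenyl would stand at this place also remains open.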